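The source may report more compounds than this note shows. Statements on the series, on what has been measured and on what is new or still open speak of the compounds shown alone.

Measured so far in a physicochemical assay for lipophilicity, using the shake flask method, measured as octanol-water partition, at pH 7.4; on this read-out lower numbers stand for lower lipophilicity and higher numbers for higher lipophilicity:
- compound 1 `COc1cc(C(=O)N2CCCC2)ccc1-c1ccnc2[nH]c(C3CCOCC3)cc12`: 3
- compound 2 `COc1cc(F)ccc1-c1ccnc2[nH]c(C3CCN(C(C)=O)CC3)cc12`: 3.4

Of these two compounds, compound 2 stands highest at 3.4, and its gap to compound 1 lies beyond the scatter of this assay. The next structure to be measured is compound 3 `COc1cc(F)ccc1-c1ccnc2[nH]c(C3CCOCC3)cc12`. It has oxan-4-yl in place of the 1-acetylpiperidin-4-yl of compound 2 (oxan-4-yl in place of 1-acetylpiperidin-4-yl on an aromatic carbon). The exchange takes place on an aromatic carbon of a five-membered aromatic ring with 1 nitrogen, part of a fused or bridged system of two rings, next to the ring nitrogen.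

Going by the values given here, no measured step shows this exchange on its own. Compound 3 differs elsewhere from compound 1, which carries the same oxan-4-yl at 3 and so offers no direct comparison. The expectation therefore remains loose: a small rise within the scatter, with a number 0.20 log units higher from compound 2 to compound 3 (within the scatter) as the estimated step. The expected value for compound 3 is 3.6, with an estimated range from 3.2 to 4.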

Compound 3, distribution coefficient: 3.9
Beside the measured number, compound 3's estimate is 0.30 log units below it; measured number inside the range.
By their numbers in this assay, from the lowest: compound 1; then compound 2; then compound 3.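

Going by these compounds alone, the first single-place reading at this position in this assay is oxan-4-yl in place of 1-acetylpiperidin-4-yl on an aromatic carbon of a five-membered aromatic ring with 1 nitrogen, which gives a number 0.50 log units higher from compound 2 to compound 3 (beyond the scatter) with the rest of the structure unchanged, so the group that leaves, with its additional heavy atoms and its double bond outside aromatic rings, goes with the lower number in this pair. Compound 3 also opens a second single-place comparison elsewhere on the core, where fluoro in place of (pyrrolidin-1-yl)carbonyl on an aromatic carbon gives a number 0.90 log units higher from compound 1 to compound 3 (beyond the scatter) while oxan-4-yl stays in place, showing that both of these exchanges move the number beyond the scatter. The data shown offer no measurement that explains either step.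

As far as these compounds go, each exchange is seen only once, on one partner group, so it remains open whether the step from compound 2 to compound 3 would keep its size with the (pyrrolidin-1-yl)carbonyl group in place of fluoro. From the compounds shown here alone, it is equally open where a plain cyclohexyl ring or a piperidin-4-yl ring with a free amine would fall at this position.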